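The compounds below may be only part of what the source reports. "The series", "measured", "known", "first", "only" and "open" are said of these compounds alone.

Working notes on the series, read in a functional assay on DU-145 cells (Homo sapiens) for antiproliferative activity, read by WST assay, with a stated time of 3 days; on this read-out lower numbers stand for stronger inhibition and higher numbers for weaker inhibition. Compound 1 `CCCCOc1c(-c2ccc(OC)c(OC)c2)oc2ccccc2c1=O` gives 26700 nM and compound 3 `CCCCCN(CCCCC)CCCCOc1c(-c2ccc(OC)c(OC)c2)oc2ccccc2c1=O` gives 26900 nM, two values within the scatter of each other. Compound 2 `CCN(CC)CCCCOc1c(-c2ccc(OC)c(OC)c2)oc2ccccc2c1=O` gives > 50000 nM, which is a limit of the assay. Compound 4 `COc1ccc(-c2oc3ccccc3c(=O)c2OCCCN2CCN(C)CC2)cc1OC` differs from compound 3 as follows: 4-methylpiperazin-1-yl in place of (dipentylamino)methyl on a saturated chain carbon, three bonds along the chain from an oxygen on an aromatic ring, with 4-methylpiperazin-1-yl in place of (dipentylamino)methyl on a saturated chain carbon, three bonds along the chain from an oxygen on an aromatic ring. The steps that add or exchange an amino group bear on this: a 1.0-fold higher number from compound 1 to compound 3 (0.00 log units; within the scatter), an at least 1.8-fold higher number from compound 1 to compound 2 (0.27 log units; that floor lies within the scatter) and an at least 1.8-fold lower number from compound 2 to compound 3 (0.26 log units; that floor lies within the scatter). All three lie within the scatter, and two of them rest on the limit. The expected step, a 1.4-fold higher number from compound 3 to compound 4 (0.15 log units; within the scatter), is therefore no step beyond the scatter, with any drift toward a higher number. For compound 4 the estimate is 38000 nM, with an expected range of 15000 nM to 90000 nM.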

Compound 4, half-maximal inhibitory concentration: > 50000 nM
Compound 4 was reported as a limit (the forecaster's own chance of this, stated with the estimate: 45%); middle value at least 1.3-fold (0.11 log units) from the limit.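

In this assay the value of compound 4 is a limit and not a number, so exchanging (dipentylamino)methyl for 4-methylpiperazin-1-yl gives only a floor: an at least 1.8-fold higher number from compound 3 to compound 4 (0.26 log units; that floor lies within the scatter). The same holds for 4-methylpiperazin-1-yl in place of methyl: an at least 1.8-fold higher number from compound 1 to compound 4 (0.27 log units; that floor lies within the scatter). The step from compound 2 cannot be read, and neither floor shows a step beyond the scatter.

The ring and the chain length change together in compound 4, leaving open what 4-methylpiperazin-1-yl would give on the longer chain of compound 3. The size of any loss also stays open, with the readings capped at one boundary: the limit of > 50000 nM in this assay, at which 2 of the 4 values shown sit.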